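Swapping the aryl on the amide-type nitrogen

The source may report more compounds than this note shows. Statements on the series, on what has been measured and on what is new or still open speak of the compounds shown alone.

Compound 1 `COc1cc(Nc2ncnc3c(NC(=O)Nc4cc(F)cc(F)c4)cccc23)cc(OC)c1`: 2630 nM
Compound 2 `COc1cc(Nc2ncnc3c(NC(=O)Nc4cccc(C)c4C)cccc23)cc(OC)c1`: 5910 nM
Compound 3 `COc1cc(Nc2ncnc3c(NC(=O)Nc4cccc(C(F)(F)F)c4F)cccc23)cc(OC)c1`: 471 nM

Three compounds share one core and differ only in the aryl group attached to an amide-type nitrogen. In a functional assay on RT-112 cells (Homo sapiens) for antiproliferative activity, read by MTT assay, with a stated time of 72 h (a higher number here means a weaker inhibitor of growth, a lower number a stronger inhibitor of growth), compound 1 gives 2630 nM, the second highest of the three numbers. Its nearest neighbour is compound 2, reached by a 2.2-fold higher number from compound 1 to compound 2 (0.35 log units; beyond the scatter). Compound 3 lies furthest from it, reached by a 5.6-fold lower number from compound 1 to compound 3 (0.75 log units; beyond the scatter); between the other two there is a 13-fold lower number from compound 2 to compound 3 (1.10 log units; beyond the scatter).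

Compound 4 `CCOC(=O)c1ccc(NC(=O)Nc2cccc3c(Nc4cc(OC)cc(OC)c4)ncnc23)cc1` has not yet been measured. It differs from compound 1 in one place: 4-(ethoxycarbonyl)phenyl in place of 3,5-difluorophenyl on an amide-type nitrogen. Among the compounds with values here, neither measured step introduces a 4-(ethoxycarbonyl)phenyl group, so no step bears directly on this change; the two steps away from compound 1 show only that exchanging the aryl on this nitrogen can move the number either way, modestly upward for compound 2 and more strongly downward for compound 3. With no closer guide, compound 4 is expected to stay near compound 1, with wide uncertainty: a 1.3-fold higher number from compound 1 to compound 4 (0.12 log units; within the scatter). The estimate for compound 4 in this assay is 3500 nM, within 1000 nM to 12000 nM.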

Compound 4, concentration for 50% growth inhibition: 317 nM
For compound 4 the middle estimate is 11-fold (1.04 log units) above the measured one; measured number below the stated range.
By their numbers in this assay, from the lowest: compounds 4 and 3 (each within the scatter of the next); then compound 1; then compound 2.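

In this assay, placing 4-(ethoxycarbonyl)phenyl on the amide-type nitrogen gives an 8.3-fold lower number from compound 1 to compound 4 (0.92 log units; beyond the scatter) and a 19-fold lower number from compound 2 to compound 4 (1.27 log units; beyond the scatter), so a low number at this position does not depend on the fluorine-bearing aryl of compound 3, and the fluorines of compound 1 do not by themselves bring one. The entering group holds carbon and oxygen only and carries 2 hydrogen-bond acceptors, yet it cannot be separated from the 2-fluoro-3-(trifluoromethyl)phenyl group, since the comparison gives a 1.5-fold lower number from compound 3 to compound 4 (0.17 log units; within the scatter), which lies within the scatter. Two aryl groups with quite different substituents therefore reach the same level at this nitrogen, although nothing available here explains the shift away from compound 1.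

The compounds shown leave open whether the ethyl ester itself matters, or whether a carboxylic acid, a methyl ester or a primary amide in place of the ethoxycarbonyl group would give a similar number. They also leave open what an unsubstituted phenyl ring would give on this nitrogen, which would show how much of the step belongs to the ester.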